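A few compounds are considered here, and "the series" means these few. Any claim that something is new, unique, unknown or untested is made for them only; others in the source may bear on it.

Measured compounds:
- compound 1, `O=C1Nc2c(ccc(F)c2F)C1(c1ccccc1)c1ccc(O)cc1`: 8.9 nM
- compound 2, `O=C1Nc2c(ccc(F)c2F)C1(c1ccc(O)cc1)c1ccc(F)cc1`: 8.6 nM
- compound 3, `COc1ccc(C2(c3ccc(O)cc3)C(=O)Nc3c2ccc(F)c3F)cc1`: 2 nM; 2.2 nM; > 1000 nM (3 entries), given as three entries

In a functional assay on PC-3 cells (Homo sapiens) for cytotoxicity, read by WST assay, with a stated time of 72 h (a higher number here means a weaker inhibitor, a lower number a stronger inhibitor), compound 1 gives 8.9 nM, the highest of the two plain numbers available. Compound 2 lies within the scatter of it: a 1.0-fold lower number from compound 1 to compound 2 (0.01 log units; within the scatter). For compound 3 the picture is mixed, since the several entries of compound 3 in this assay, 2 nM; 2.2 nM; > 1000 nM (3 entries) holds two close numbers and one entry that is only a limit.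

Compound 4, `O=C1Nc2c(ccc(F)c2F)C1(c1ccc(O)cc1)C1CCCC1`, keeps the shared core of compound 1 but differs in one place: cyclopentyl in place of phenyl on a saturated ring carbon. Going by the values given here, the only measured step, from compound 1 to compound 2, swaps fluoro for hydrogen on an aromatic carbon and changes nothing beyond the scatter, so it gives no guidance on exchanging an aromatic ring for a non-aromatic one. Among the compounds with values here, no measured step covers a change of this kind.

Within the data shown here, with no precedent, the expectation can only be a cautious one. Compound 4 is expected to give 30 nM, in a range from 5 nM to 300 nM. That estimate means a step of a 3.4-fold higher number from compound 1 to compound 4 (0.53 log units; beyond the scatter), a loss of potency that is expected but uncertain in size.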

Compound 4, half-maximal inhibitory concentration: 8.2 nM
Compound 4: the middle estimate sits 3.7-fold (0.56 log units) above what was measured; the measured number falls inside the stated range.
By their numbers in this assay, from the lowest: compounds 4, 2 and 1 (each within the scatter of the next).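

In this assay, replacing the aromatic ring on the saturated ring carbon with cyclopentyl gives a 1.1-fold lower number from compound 1 to compound 4 (0.04 log units; within the scatter), and replacing the 4-fluorophenyl group gives a 1.0-fold lower number from compound 2 to compound 4 (0.02 log units; within the scatter), so both steps stay within the scatter. The earlier step only varied a fluoro on an aromatic ring that stayed in place, whereas these two show that, at this position and for these compounds, an aromatic ring is not required for a low-nanomolar number: a non-aromatic ring of carbon only does as well. Nothing in the data at hand explains why these rings can stand in for one another.

From the compounds shown here alone, all of the groups compared at this position are rings of carbon, so it remains open how an open chain such as isopropyl or a longer chain would fare, or a smaller ring such as cyclopropyl, or a cyclopentyl ring carrying an amine or a carboxylic acid. Compound 3 offers no single number to set beside cyclopentyl, since one of its three entries is only a limit and that entry disagrees with the other two.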